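Swapping sulfamoyl for methylamino on the chloroindole sulfonamide

The source may hold more compounds than are shown below. What is called first, only, known or untested is meant among the compounds shown, and "the series" means these compounds.

This account follows three measured compounds and one whose number is still to come. Compound 1 `NS(=O)(=O)c1ccc(S(=O)(=O)Nc2cccc3c(Cl)c[nH]c23)cn1` carries a sulfamoyl group on its six-membered aromatic ring with one nitrogen; in a functional assay on HCT-116 cells (Homo sapiens) for inhibition, with a stated time of 72 h (on this read-out lower numbers stand for stronger inhibition and higher numbers for weaker inhibition), compound 1 gives 290 nM. Compound 2 `N#Cc1c[nH]c2c(NS(=O)(=O)c3cccnc3)cccc12` gives 230 nM and compound 3 `N#Cc1c[nH]c2c(NS(=O)(=O)c3ccc(N)nc3)cccc12` gives 640 nM. On these numbers compound 1 stands second highest of the three, within the scatter of compound 2 and beyond it relative to compound 3.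

Compound 4 `CNc1ccc(S(=O)(=O)Nc2cccc3c(Cl)c[nH]c23)cn1` differs from compound 1 in one place: methylamino in place of sulfamoyl on an aromatic carbon. Among the compounds with values here, the only measured step that touches the same ring is a 2.8-fold higher number from compound 2 to compound 3 (0.44 log units; beyond the scatter), seen in the nitrile series. That step was modest and upward, but the present change removes sulfamoyl rather than adding to hydrogen, so it bears only loosely.

The author therefore expects a modest upward step, a 1.7-fold higher number from compound 1 to compound 4 (0.24 log units; within the scatter), and estimates compound 4 at 500 nM, within 200 nM to 1500 nM.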

Compound 4, half-maximal inhibitory concentration: 860 nM
Estimate against measurement, compound 4: 1.7-fold (0.24 log units) below, and the stated range covers the measured number.
By their numbers in this assay, from the lowest: compounds 2 and 1 (each within the scatter of the next); then compounds 3 and 4 (each within the scatter of the next).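

Methylamino in place of sulfamoyl, on an aromatic carbon next to the ring nitrogen, brings a 3.0-fold higher number from compound 1 to compound 4 (0.47 log units; beyond the scatter) in this assay. Within the data shown here, until now the only step at this place was a 2.8-fold higher number from compound 2 to compound 3 (0.44 log units; beyond the scatter), where amino replaced hydrogen in a compound with a nitrile; the new step shows that the read-out also moves beyond the scatter when an existing sulfamoyl group is exchanged on the core of compound 1, and that a group with a nitrogen attached directly to this carbon again comes with a higher number. No measurement shown here accounts for this step.

As far as these compounds go, it remains open how a carboxylic acid or a dimethylamino group would read at this place on the core of compound 1. From the compounds shown here alone, whether methylamino would give a similar step with the nitrile in place of the chlorine also remains open.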